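The source may hold more compounds than are shown below. What is called first, only, known or untested is meant among the compounds shown, and "the series" means these compounds.

Three compounds share one core and differ only in the group carried on an amine nitrogen in a ring. Compound 1 `CCCn1c(=O)[nH]c2nc(-c3ccc(S(=O)(=O)N4CCN(c5ccc(Br)cc5)CC4)cc3)[nH]c2c1=O` bears 4-bromophenyl there, and in an assay on CHO cells for displacement of a labelled ligand from adenosine receptor A3 (Homo sapiens), read by scintillation counting, with a stated time of 45 min, tested at 1 uM, in the presence of a further agent that is not named here (on this read-out lower numbers stand for less inhibition and higher numbers for more inhibition at the one concentration tested (going by the name of the read-out)), compound 1 gives 29%. Compound 2 `CCCn1c(=O)[nH]c2nc(-c3ccc(S(=O)(=O)N4CCN(Cc5cccc(C)c5)CC4)cc3)[nH]c2c1=O` bears 3-methylbenzyl, and in this assay compound 2 gives 17%. Compound 3 `CCCn1c(=O)[nH]c2nc(-c3ccc(S(=O)(=O)N4CCN(C)CC4)cc3)[nH]c2c1=O` bears methyl, and in this assay compound 3 gives 7%, the lowest of the three numbers; its gap to compound 2 is within the scatter, whereas the step of a number 22 percentage points lower from compound 1 to compound 3 (beyond the scatter) lies beyond it.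

Compound 4 `CCCn1c(=O)[nH]c2nc(-c3ccc(S(=O)(=O)N4CCN(c5ccccc5F)CC4)cc3)[nH]c2c1=O` is the next case: 2-fluorophenyl in place of methyl on an amine nitrogen in a ring. The step that bears most directly on this change is a number 22 percentage points lower from compound 1 to compound 3 (beyond the scatter), since compound 4 reverses it by putting an aromatic ring back on that nitrogen, now carrying fluorine rather than bromine. The steps of a number 12 percentage points lower from compound 1 to compound 2 (beyond the scatter) and a number 10 percentage points lower from compound 2 to compound 3 (within the scatter) point the same way, the second of them within the scatter. Only compound 1 shows what an aryl group on this nitrogen does, so the expectation rests on a single comparison.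

For compound 4 the expected step is a number 18 percentage points higher from compound 3 to compound 4 (beyond the scatter), a modest rise in this assay. Compound 4 is estimated at 25%, with a range from 10% to 40%.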

Compound 4, a percentage reported as inhibition, at one concentration (the size of the read-out at that concentration, not a potency): 9%
The estimate for compound 4 lay 16 percentage points above the measured number; the measured number lies below the stated range.
By their numbers in this assay, from the lowest: compounds 3, 4 and 2 (each within the scatter of the next); then compound 1.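

Compound 4 shows that an aromatic ring on this amine nitrogen does not by itself raise the number in this assay: putting 2-fluorophenyl in place of methyl gives a number 2 percentage points higher from compound 3 to compound 4 (within the scatter), and putting it in place of 3-methylbenzyl gives a number 8 percentage points lower from compound 2 to compound 4 (within the scatter), so neither change separates the compounds. Going by these compounds alone, the earlier comparison had only one aryl group on this nitrogen, and the second now shows that aryl groups can differ: 2-fluorophenyl in place of 4-bromophenyl gives a number 20 percentage points lower from compound 1 to compound 4 (beyond the scatter), a modest step beyond the scatter. Among the compounds shown, the higher number therefore belongs to 4-bromophenyl in particular and not to aryl groups in general, and no evidence here explains this difference.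

The two aryl groups differ in both the halogen and where it sits on the ring, so the compounds shown cannot tell which of these matters. On these data alone, how 4-fluorophenyl, 2-bromophenyl or a phenyl ring carrying an amine or a carboxylic acid would read in this assay remains open.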